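Cinnamamide variation on a trimethoxybenzophenone aniline

This account rests on a few compounds, and the source may have more. Where it says the series, first, only, none or still open, it means among the compounds named here.

Compound 3 `C#CCOc1cccc(/C=C/C(=O)Nc2cc(C(=O)c3cc(OC)c(OC)c(OC)c3)ccc2OC)c1` gives 13100 nM in a functional assay on PC-3 cells (Homo sapiens) for cytotoxicity, read by MTT assay, with a stated time of 72 h (on this read-out lower numbers stand for stronger inhibition and higher numbers for weaker inhibition), the highest of the three numbers recorded. Compound 2 `COc1cccc(/C=C/C(=O)Nc2cc(OC)c(OC)c(OC)c2)c1` gives 2100 nM, and compound 1 `COc1ccc(C(=O)c2cc(OC)c(OC)c(OC)c2)cc1N`, the free aniline, gives 1100 nM; both gaps to compound 3 lie beyond the scatter, so compound 3 stands as the weakest of the measured set in this assay. Compound 4 `COc1ccc(C(=O)c2cc(OC)c(OC)c(OC)c2)cc1NC(=O)/C=C/c1ccc([N+](=O)[O-])cc1` keeps the whole of compound 3 apart from one change: 4-nitrophenyl in place of 3-(propargyloxy)phenyl on a double-bonded chain carbon bound to a double-bonded chain carbon. Going by the values given here, no pair differing in one place has been measured, so the size of this kind of step is not known from the series. Only the change of the aryl group on the cinnamoyl chain separates compound 4 from compound 3, and nothing measured ties that aryl group to the read-out. For compound 4 the expected step of a 1.5-fold lower number from compound 3 to compound 4 (0.16 log units; within the scatter) is therefore small, not beyond the scatter, with the estimate for compound 4 set at 9000 nM, the range running from 3000 nM to 30000 nM.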

Compound 4, half-maximal inhibitory concentration: 10400 nM
The estimate for compound 4 lay 1.2-fold (0.06 log units) below the measured number; low and high end bracket the measured number.
By their numbers in this assay, from the lowest: compounds 1 and 2 (each within the scatter of the next); then compounds 4 and 3 (each within the scatter of the next).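

In this assay, going by these compounds alone, the exchange of 3-(propargyloxy)phenyl for 4-nitrophenyl on a double-bonded chain carbon bound to a double-bonded chain carbon gives a 1.3-fold lower number from compound 3 to compound 4 (0.10 log units; within the scatter) and so supplies the only one-place step. At this position the read-out does not separate the two aryl groups, although the triple bond leaves and 4-nitrophenyl brings in different atoms, so compound 3 and compound 4 stand together within the usual scatter. Nothing on hand offers a reason for so small a step.

Open, as far as these compounds go, is whether any group at this position moves the number beyond the scatter, for example a phenyl ring carrying an amine or a carboxylic acid. From the compounds shown here alone, a longer chain in place of the ethenyl link also remains open.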